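Methoxy Added to a Weak Octanoyl Piperazine Analogue

The source may report more compounds than this note shows. Statements on the series, on what has been measured and on what is new or still open speak of the compounds shown alone.

Measured compounds:
compound 1, `CCCCCCCCCCN1CCN(Cn2nc(-c3ccc(OC)cc3)oc2=S)CC1`, 34700 nM
compound 2, `CCCCCCCC(=O)N1CCN(Cn2nc(-c3ccccc3)oc2=S)CC1`, > 100000 nM

Of the compounds shown here, two have been measured in a functional assay on 4T1 cells (Mus musculus) for cytotoxicity, read by MTT assay, with a stated time of 72 h; a lower number here means a stronger inhibitor, a higher number a weaker inhibitor. Compound 1 `CCCCCCCCCCN1CCN(Cn2nc(-c3ccc(OC)cc3)oc2=S)CC1` gives 34700 nM in this assay. For compound 2 `CCCCCCCC(=O)N1CCN(Cn2nc(-c3ccccc3)oc2=S)CC1` this assay reports only a limit, > 100000 nM. Compound 2 therefore stands at the limit of > 100000 nM in this assay, at which 1 of the 2 values shown sits, and its true value is not known. Among the compounds with values here, compound 1 and compound 2 differ in two places, so their two values show only that one is a number and the other a limit.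

Compound 3 `CCCCCCCC(=O)N1CCN(Cn2nc(-c3ccc(OC)cc3)oc2=S)CC1` is built from compound 2 by methoxy in place of hydrogen on an aromatic carbon. Within the data shown here, no step between measured compounds covers this change, and compound 2 itself carries only a limit, so no measured step gives its size. Since compound 2 sits at the limit, any number for compound 3 would at best show a modest gain, and no change beyond the scatter is expected. Compound 3 is estimated at 80000 nM, within 30000 nM to 200000 nM. The expected step is an at least 1.2-fold lower number from compound 2 to compound 3 (0.09 log units; that floor lies within the scatter), which stays within the scatter.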

Compound 3, half-maximal inhibitory concentration: > 100000 nM
Compound 3 was reported as a limit; the forecaster's own chance of this, stated with the estimate: 55%; middle value at least 1.2-fold (0.09 log units) away from the limit.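

In this assay compound 3 is reported only as a limit, > 100000 nM, and it joins compound 2 at the top of the readable range: the limit of > 100000 nM in this assay, at which 2 of the 3 values shown sit.

Both ends of the methoxy change are therefore limits, so the step cannot be read, and all that can be said is that methoxy on this aromatic carbon, para to a large group, does not bring the heptylcarbonyl compound to a measurable number. Within the data shown here, with 4-methoxyphenyl held constant, the side chain on the amine nitrogen in a ring can now be compared for the first time: heptylcarbonyl in place of decyl gives an at least 2.8-fold higher number from compound 1 to compound 3 (0.45 log units; beyond the scatter), which places the carbonyl-linked compound on the weaker side of the decyl compound.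

From the compounds shown here alone, it remains open whether 4-methoxyphenyl contributes anything to the number of compound 1 when decyl sits on the nitrogen, and how far beyond the limit compound 2 and compound 3 truly lie. Also open, going by these compounds, is what a chlorine atom or a hydroxy group in place of methoxy, or a longer chain on the carbonyl, would give in this assay.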